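This account rests on a few compounds, and the source may have more. Where it says the series, first, only, none or still open, it means among the compounds named here.

Measured in an ADME assay on microsomes from liver (Mus musculus) for metabolic stability, read by LC-MS, using NADPH, with stated times of 10 min and 30 min, tested at 1 uM; on this read-out lower numbers stand for slow clearance and higher numbers for fast clearance:
- compound 1 `COC(=O)C1=C(CN2CCOCC2=O)NC(c2nccs2)=NC1(C)c1ccc(F)cc1`: 80 mL/min/kg
- compound 2 `COC(=O)C1=C(CN2CCNC(=O)C2)NC(c2nccs2)=NC1(C)c1ccc(F)cc1`: 81 mL/min/kg
- compound 3 `COC(=O)C1=C(CN2CCC(O)CC2)NC(c2nccs2)=NC1(C)c1ccc(F)cc1`: 81 mL/min/kg

On these numbers, compound 3 stands level with compound 2 and within the scatter of compound 1, so the three compounds cannot be ranked in this assay.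

The next step leads from compound 3 to compound 4 `COC(=O)C1=C(CN2CCC(O)C2)NC(c2nccs2)=NC1(C)c1ccc(F)cc1`. It places 3-hydroxypyrrolidin-1-yl in place of 4-hydroxypiperidin-1-yl on a saturated chain carbon bound to a double-bonded ring carbon.

Among the measured compounds shown here, three measured steps bear on this change, since each exchanges the group at that same place. They are a 1.0-fold higher number from compound 1 to compound 3 (0.01 log units; within the scatter), no change at the digits printed from compound 2 to compound 3 (within the scatter) and a 1.0-fold higher number from compound 1 to compound 2 (0.01 log units; within the scatter). All three lie within the scatter, even though the groups exchanged differ from one another. For the measured compounds named here, none of them, however, goes from a six-membered to a five-membered ring, so the data offer no direct precedent for this change.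

The expectation therefore rests on the flat behaviour of these three compounds, and no change beyond the scatter is foreseen. The estimated step is a 1.0-fold lower number from compound 3 to compound 4 (0.02 log units; within the scatter). For compound 4 the expected clearance is 78 mL/min/kg, with an estimated range of 50 mL/min/kg to 110 mL/min/kg.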

Compound 4, clearance: 83 mL/min/kg
The estimate for compound 4 lay 1.1-fold (0.03 log units) below the measured number, and the stated range covers the measured number.
By their numbers in this assay, from the lowest: compounds 1, 2, 3 and 4 (each within the scatter of the next).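

In this assay, among the compounds shown here, 3-hydroxypyrrolidin-1-yl in place of 4-hydroxypiperidin-1-yl gave a 1.0-fold higher number from compound 3 to compound 4 (0.01 log units; within the scatter) and so provided the first reading of a change from a six-membered to a five-membered ring at this position, on a saturated chain carbon bound to a double-bonded ring carbon. Set against the two lactam-bearing compounds, the same group gave a 1.0-fold higher number from compound 2 to compound 4 (0.01 log units; within the scatter) and a 1.0-fold higher number from compound 1 to compound 4 (0.02 log units; within the scatter) and, with all three new steps lying within the scatter, the flat picture now extends across four different groups and both ring sizes without any compound separating from the others. No accompanying measurement offers an explanation for this flat behaviour.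

The compounds shown leave open whether a group lacking both the hydroxyl and the carbonyl, such as unsubstituted piperidin-1-yl or an open-chain dimethylamino group, or a carboxylic acid at this position would move the clearance beyond the scatter. They also leave open whether a change elsewhere on the shared core, such as an amide in place of the methyl ester carried by all four compounds, would do so.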